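A Difluorophenyl Variant of a Weak Cytotoxic Amide

The source may hold more compounds than are shown below. What is called first, only, known or untested is meant among the compounds shown, and "the series" means these compounds.

Compound 1, `O=S(=O)(Nc1cc(CO)ccc1O)c1ccc(-c2ccc(Br)cc2)cc1`: in a functional assay on J774 cells (Mus musculus) for cytotoxicity, read by resazurin assay, with a stated time of 72 h (a higher number here means a weaker inhibitor, a lower number a stronger inhibitor), compound 1 gives 1000 nM.
Compound 2, `O=C(Nc1cccc(CO)c1)c1ccc(-c2ccccc2)cc1`: in this assay compound 2 gives > 15000 nM.

The value recorded for compound 2 is a limit of this assay and not a number, so compound 2 is known only as a weak inhibitor of these cells. Where compound 2 stands is thus given only by the limit of > 15000 nM in this assay, at which 1 of the 2 values shown sits. Going by the values given here, compound 1 carries a different linker and a different substitution pattern, and no single step connects it to compound 2, so the two values show only that compound 1 is measured as a number while compound 2 is not.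

Compound 3, `O=C(Nc1cccc(CO)c1)c1ccc(-c2ccc(F)cc2F)cc1`, differs from compound 2 by 2,4-difluorophenyl in place of phenyl on an aromatic carbon. Among the compounds with values here, no measured pair shows this change, so its size is unknown. In this assay a step from compound 2 to compound 3 no larger than the usual scatter is expected, in no particular direction. Compound 3 is therefore estimated at 15000 nM, in a range from 5000 nM to 50000 nM. The expected a number no higher from compound 2 to compound 3 (the limit leaves the size open) is small, and a limit rather than a number is likely.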

Compound 3, half-maximal inhibitory concentration: > 15000 nM
Compound 3: no number, only a limit; the forecaster's own chance of this, stated with the estimate: 70%; the middle value lies on the limit itself.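

In this assay compound 3 gives > 15000 nM as a limit of the assay and not a number. Going by these compounds alone, compound 2 is also recorded only as a limit, so no step between compound 2 and compound 3 can be read. Still open, as far as these compounds go, is how strongly either compound acts on these cells, and whether 2,4-difluorophenyl in place of phenyl changes that at all.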